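A few compounds are considered here, and "the series" means these few. Any claim that something is new, unique, unknown or untested is made for them only; others in the source may bear on it.

Measured so far:
compound 1 `CCCCc1nc(N)c2nc(O)n(Cc3ccccc3)c2n1` — 0.03 uM
compound 2 `CSc1nc2c(N)ncnc2n1Cc1ccccc1` — > 10 uM

For the measured compounds named here, in a functional assay (spleen, spleen) for activation, with Mus musculus as the target (on this read-out higher numbers stand for an effect only at larger amounts of compound and lower numbers for an effect already at smaller amounts), compound 1 gives 0.03 uM, the only full number among the two values shown. For compound 2 the result is a limit of the assay, not a number: it gives > 10 uM (the limit of > 10 uM in this assay, at which 1 of the 2 values shown sits). Compound 3 `COc1nc(N)c2nc(O)n(Cc3ccccc3)c2n1` has not been measured. It differs from compound 1 by methoxy in place of butyl on an aromatic carbon. Going by the values given here, no step between measured compounds is known, so the expected step is an estimate: the loss of the butyl chain is expected to cost some activity, a 3.3-fold higher number from compound 1 to compound 3 (0.52 log units; beyond the scatter), in this assay. Compound 3 is estimated at 0.1 uM, between 0.02 uM and 0.6 uM.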

Compound 3, minimum effective concentration: 0.1 uM
Beside the measured number, compound 3's estimate shows no gap at the digits printed; the measured number falls inside the stated range.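

In this assay, for the compounds shown here, putting methoxy in place of butyl on the aromatic carbon between two ring nitrogen atoms gives a 3.3-fold higher number from compound 1 to compound 3 (0.52 log units; beyond the scatter) and this is the first measured view of this position. The loss is modest, so the full butyl chain is useful here but not essential for an effect at small amounts. Nothing shown accounts for the size of this step.

On these data alone, whether the shorter length or the oxygen matters more stays open, and an ethyl chain at this carbon would help separate them. As far as these compounds go, how an amine or a longer chain such as hexyl would behave here is also open.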